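Anilide ureas: alkyl growth on the aromatic ring

The compounds below may be only part of what the source reports. "The series", "measured", "known", "first", "only" and "open" are said of these compounds alone.

Measured compounds:
Compound 1, `Cc1ccc(NC(=O)N[C@@H](C)c2ccccc2)cc1`, in an ADME assay on the whole organism with Oryza sativa as the target, tested at 1 uM (on this read-out higher numbers stand for a weaker effect at the one concentration tested and lower numbers for a stronger effect), gives 99%.
Compound 2, `CCc1ccccc1NC(=O)N[C@H](C)c1ccccc1`, in this assay gives 100%.
Compound 3, `CCc1ccc(NC(=O)N[C@@H](C)c2ccccc2)cc1`, in this assay gives 95%.

The three measured values lie within the usual scatter of one another, so nothing separates these compounds on this assay. For the measured compounds named here, the one counted change among them, (methyl in place of hydrogen on a saturated chain carbon bound to an aromatic carbon), gives the step of a number 4 percentage points lower from compound 1 to compound 3 (within the scatter). The difference between the cores of compound 1 and compound 2 is not broken down here.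

Compound 4, `CC(C)c1ccccc1NC(=O)N[C@H](C)c1ccccc1`, is not yet measured. Against compound 2 it shows (methyl in place of hydrogen on a saturated chain carbon bound to an aromatic carbon and a saturated chain carbon). Going by the values given here, this is the same kind of change as the one from compound 1 to compound 3, though not the same: in the earlier case the place is on a saturated chain carbon bound to an aromatic carbon, whereas here the place is on a saturated chain carbon bound to an aromatic carbon and a saturated chain carbon.

Among the compounds with values here, the expectation rests on the only step of this kind that has been measured, a number 4 percentage points lower from compound 1 to compound 3 (within the scatter), which stayed within the scatter. For compound 4 the expected step is a number 3 percentage points lower from compound 2 to compound 4 (within the scatter). Compound 4 is therefore estimated at 97%, with a likely range from 85% to 100%.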

Compound 4, a percentage reported as activity, at one concentration (the size of the read-out at that concentration, not a potency): 101%
Compound 4: middle estimate off by 4 percentage points, on the low side; the measured number lies above the stated range.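

The new step is a number 1 percentage points higher from compound 2 to compound 4 (within the scatter) in this assay and, read as ethyl to isopropyl, gives no sign of a change on the core of compound 2. Set beside the earlier step, the same replacement of hydrogen by methyl cannot be told apart on the two cores: the same change on two cores in this assay, a number 4 percentage points lower (within the scatter) from compound 1 to compound 3 and a number 1 percentage points higher (within the scatter) from compound 2 to compound 4, 5 percentage points apart, within the scatter of two such steps. This shows that, in these two cases, the change carries across the cores without a step that stands out from the scatter; it does not show that the change has no effect in general, that the two places are equivalent, or that a step of any particular size would carry over to a further core, and two steps are too few to support a rule.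

The compounds shown leave open whether anything other than a small alkyl group on the aromatic ring moves this read-out at all, for instance a longer chain such as hexyl, an amine or a carboxylic acid in the place now held by ethyl or isopropyl. Also open, as far as these compounds go, is whether any compound gives a number that stands clear of the others on this read-out.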